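A few compounds are considered here, and "the series" means these few. Any claim that something is new, unique, unknown or untested is made for them only; others in the source may bear on it.

Four compounds share one core and differ only in two outer parts. Compound 1 is `CCN(CC)CCCNc1nc(-c2ccc(NC(=O)Nc3ccc(Cl)cc3)cc2)nc2c(Cl)c(Cl)sc12`; compound 2 is `CCN(CC)CCCNc1nc(-c2ccc(NC(=O)Nc3ccccc3Cl)cc2)nc2c(Cl)c(Cl)sc12`; compound 3 is `CCN(CC)CCNc1nc(-c2ccc(NC(=O)Nc3ccc(Cl)cc3)cc2)nc2c(Cl)c(Cl)sc12`; compound 4, not yet measured, is `CCN(CC)CCNc1nc(-c2ccc(NC(=O)Nc3ccccc3Cl)cc2)nc2c(Cl)c(Cl)sc12`.

In a functional assay on NCI-H460 cells (Homo sapiens) for cytotoxicity, read by MTT assay, with a stated time of 72 h (a higher number here means a weaker inhibitor, a lower number a stronger inhibitor), compound 1 gives 270 nM. In this assay compound 2 gives 330 nM, and compound 3 gives 320 nM. The change from compound 1 to compound 2 is 2-chlorophenyl in place of 4-chlorophenyl on an amide-type nitrogen, and it made a step of a 1.2-fold higher number from compound 1 to compound 2 (0.09 log units; within the scatter). The change from compound 1 to compound 3 is diethylamino in place of (diethylamino)methyl on a saturated chain carbon, two bonds along the chain from a nitrogen on an aromatic ring, with a step of a 1.2-fold higher number from compound 1 to compound 3 (0.07 log units; within the scatter). Both steps are small, so the three measured compounds all sit close together.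

Compound 4 stands to compound 3 as compound 2 stands to compound 1: the change is 2-chlorophenyl in place of 4-chlorophenyl on an amide-type nitrogen, and the place where it happens is described in the same words for both pairs, so it is the same change. The cores of compound 3 and compound 4 differ from those of compound 1 and compound 2 only in the way given by diethylamino in place of (diethylamino)methyl on a saturated chain carbon, two bonds along the chain from a nitrogen on an aromatic ring, a difference that itself changed little.

The step from compound 3 to compound 4 is therefore expected to be about a 1.2-fold higher number from compound 3 to compound 4 (0.07 log units; within the scatter), close to the earlier one, because the earlier step of a 1.2-fold higher number from compound 1 to compound 2 (0.09 log units; within the scatter) was within the scatter. On that basis compound 4 is estimated at 380 nM in this assay, with a likely range from 200 nM to 720 nM.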

Compound 4, half-maximal inhibitory concentration: 460 nM
The estimate for compound 4 lay 1.2-fold (0.08 log units) below the measured number; low and high end bracket the measured number.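

In this assay, putting 2-chlorophenyl in place of 4-chlorophenyl on the amide-type nitrogen gave a step of a 1.4-fold higher number from compound 3 to compound 4 (0.16 log units; within the scatter), and this swap behaved alike on the two cores: the same change on two cores in this assay, a 1.2-fold higher number (0.09 log units; within the scatter) from compound 1 to compound 2 and a 1.4-fold higher number (0.16 log units; within the scatter) from compound 3 to compound 4, 1.2-fold (0.07 log units) apart, within the scatter of two such steps

The change in the chain, diethylamino in place of (diethylamino)methyl, gave a step of a 1.4-fold higher number from compound 2 to compound 4 (0.14 log units; within the scatter), and it too behaved alike on the two cores: the same change on two cores in this assay, a 1.2-fold higher number (0.07 log units; within the scatter) from compound 1 to compound 3 and a 1.4-fold higher number (0.14 log units; within the scatter) from compound 2 to compound 4, 1.2-fold (0.07 log units) apart, within the scatter of two such steps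

Among these compounds, this agreement is between small steps, so it shows only that neither change shifted the number by a readable amount on the cores compared here; it does not show that a change with a large effect would carry from one core to another in the same way, and it speaks for this one cell assay alone.

The compounds shown leave open what a plain phenyl or a 3-chlorophenyl on the amide-type nitrogen would do to the number, and whether a group other than a chlorophenyl there would give a step beyond the scatter. They also leave open how a longer chain, or a morpholine in place of the diethylamino group, would behave on these cores.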